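Removing the methyl from compound 2: working notes

The compounds below may be only part of what the source reports. "The series", "measured", "known", "first", "only" and "open" are said of these compounds alone.

In a physicochemical assay for lipophilicity, using the shake flask method (on this read-out lower numbers stand for lower lipophilicity and higher numbers for higher lipophilicity), compound 1 (`C[C@H](Oc1ccc2ncc(/C=C/S(=O)(=O)O)c(C3CC3)c2c1)c1c(Cl)ccc(F)c1Cl`) gives 2.5 and compound 2 (`Cc1c(/C=C/C(=O)O)cnc2ccc(O[C@@H](C)c3c(Cl)ccc(F)c3Cl)cc12`) gives 3 as the higher of the two numbers, with the gap between them beyond the scatter. Among the measured compounds shown here, these two compounds differ in more than one place, so no measured step isolates a single change.

Compound 3 (`C[C@H](Oc1ccc2ncc(/C=C/C(=O)O)cc2c1)c1c(Cl)ccc(F)c1Cl`) has no number yet. Its change from compound 2 is hydrogen in place of methyl on an aromatic carbon and in words it is hydrogen in place of methyl on an aromatic carbon, ortho to a 2-carboxyethenyl group and opposite the ring nitrogen.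

For the measured compounds named here, with no measured step to draw on, compound 2 at 3 serves as the only anchor for the expectation. A modest fall is expected in this assay rather than a rise, with the estimated step being a number 0.40 log units lower from compound 2 to compound 3 (beyond the scatter) and only a little beyond the scatter. For compound 3 the estimated value is 2.6 with an expected range from 2.2 to 3 for now.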

Compound 3, distribution coefficient: 2.5
Beside the measured number, compound 3's estimate is 0.10 log units above it; the range from low to high includes it.
By their numbers in this assay, from the lowest: compounds 1 and 3 (each within the scatter of the next); then compound 2.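

In this assay, the change of hydrogen in place of methyl on an aromatic carbon, ortho to a 2-carboxyethenyl group and opposite the ring nitrogen, gives a number 0.50 log units lower from compound 2 to compound 3 (beyond the scatter). Among the compounds shown here, this is the first step that can be tied to one place, since compounds 1 and 2 differ in more than one place and their gap could not be assigned to any single change. The read-out therefore responds to this position on its own, at least for this pair with the 2-carboxyethenyl group in place, but nothing at hand accounts for the size of the step.

The compounds shown leave open how the read-out would respond to other groups at this same position, such as an ethyl, a methoxy or an amine, and whether its response follows the size of the group or depends on its type. Also open, as far as these compounds go, is whether the step from methyl to hydrogen would keep its size if the 2-carboxyethenyl group were replaced by another chain, such as a simple propanoic acid or an amide.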